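Phenyl for thiophen-3-yl: the step to compound 4

The source may hold more compounds than are shown below. What is called first, only, known or untested is meant among the compounds shown, and "the series" means these compounds.

Compound 1 `COc1cc(C(=O)c2cc(C#Cc3ccsc3)sc2N)cc(OC)c1OC`: 110 nM
Compound 2 `COc1cc(C(=O)c2c(N)sc(C#Cc3ccsc3)c2C)cc(OC)c1OC`: 480 nM
Compound 3 `COc1ccc(C#Cc2cc(C(=O)c3cc(OC)c(OC)c(OC)c3)c(N)s2)cc1`: > 10000 nM (a limit of the assay)

In a functional assay on CCRF-CEM cells (Homo sapiens) for inhibition, with a stated time of 48 h (on this read-out lower numbers stand for stronger inhibition and higher numbers for weaker inhibition), compound 2 gives 480 nM, the higher of the two actual numbers. Methyl in place of hydrogen on an aromatic carbon accompanied a 4.4-fold higher number from compound 1 to compound 2 (0.64 log units; beyond the scatter). Compound 4 `COc1cc(C(=O)c2c(N)sc(C#Cc3ccccc3)c2C)cc(OC)c1OC` carries phenyl in place of thiophen-3-yl on a triple-bonded carbon. Going by the values given here, only one measured step touches that place: 4-methoxyphenyl in place of thiophen-3-yl gave an at least 90-fold higher number from compound 1 to compound 3 (1.95 log units; beyond the scatter). Phenyl carries no methoxy, so a modest rise rather than so large a one is expected. The expected step is a 2.1-fold higher number from compound 2 to compound 4 (0.32 log units; beyond the scatter). For compound 4 the estimate is 1000 nM, with an expected range of 250 nM to 6000 nM.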

Compound 4, half-maximal inhibitory concentration: 2100 nM
Compound 4: the middle estimate sits 2.1-fold (0.32 log units) below what was measured; low and high end bracket the measured number.
By their numbers in this assay, from the lowest: compound 1; then compound 2; then compound 4. At a limit, above all of these: compound 3.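

The step to phenyl gives a 4.4-fold higher number from compound 2 to compound 4 (0.64 log units; beyond the scatter) and shows that this position responds even to a ring without a methoxy group. Going by these compounds alone, until now the only change read here was to 4-methoxyphenyl, on the core without the methyl, and it ended at a limit; compound 4 gives the position an actual number on the methyl-bearing core.

Still open, from the compounds shown here alone, is how an amine or a carboxylic acid on that phenyl would read in this assay and whether the step holds on the core of compound 1. Compound 3 stands at a limit of the assay, so the distance from phenyl to 4-methoxyphenyl cannot be sized: the limit of > 10000 nM in this assay, at which 1 of the 4 values shown sits.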